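A methoxyphenyl replaces a dimethylphenyl on the shared core

The source may report more compounds than this note shows. Statements on the series, on what has been measured and on what is new or still open speak of the compounds shown alone.

Compound 3 `Cc1ccc(NC2=CC(=O)c3nc4n(c3C2=O)[C@H]2OC[C@@H](O)[C@H]2OC4)cc1C` carries a 3,4-dimethylphenyl on the amine nitrogen and in a functional assay on MGC-803 cells (Homo sapiens) for inhibition, read by sulforhodamine B assay (on this read-out lower numbers stand for stronger inhibition and higher numbers for weaker inhibition), compound 3 gives 860 nM. For the measured compounds named here, that is the lowest of the three numbers measured so far. Compound 1 `O=C1C=C(Nc2ccc(I)cc2)C(=O)c2c1nc1n2[C@H]2OC[C@@H](O)[C@H]2OC1`, with a 4-iodophenyl in that place, gives 1400 nM, and the step of a 1.6-fold lower number from compound 1 to compound 3 (0.21 log units; within the scatter) is within the scatter. Compound 2 `COc1cccc(NC2=CC(=O)c3c(nc4n3[C@H]3OC[C@@H](O)[C@H]3OC4)C2=O)c1`, which carries a 3-methoxyphenyl on a differently built core, gives 1790 nM, beyond the scatter from compound 3.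

Compound 4 `COc1cccc(NC2=CC(=O)c3nc4n(c3C2=O)[C@H]2OC[C@@H](O)[C@H]2OC4)c1` differs from compound 3 in one place: 3-methoxyphenyl in place of 3,4-dimethylphenyl on an amine nitrogen. Going by the values given here, no measured step covers this exact exchange. Among the compounds with values here, the one step between aryl groups on the same core, from compound 1 to compound 3, stayed within the scatter, and the only compound carrying a 3-methoxyphenyl, compound 2, sits somewhat higher than compound 3. Compound 4 is therefore expected to give a number a little above compound 3, a step of a 1.7-fold higher number from compound 3 to compound 4 (0.24 log units; within the scatter), though this may well stay within the scatter. The estimate for compound 4 in this assay is 1500 nM, with a range from 700 nM to 3200 nM.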

Compound 4, half-maximal inhibitory concentration: 1780 nM
For compound 4 the middle estimate is 1.2-fold (0.07 log units) below the measured one; the range from low to high includes it.
By their numbers in this assay, from the lowest: compounds 3, 1, 4 and 2 (each within the scatter of the next, the first and the last beyond it).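

For the compounds shown here, on the amine nitrogen of the shared core, the step of a 2.1-fold higher number from compound 3 to compound 4 (0.32 log units; beyond the scatter) is the first exchange of aryl groups at this position to go beyond the scatter, so the choice of aryl group can register in this read-out. It is a modest step, however, and the other new step, a 1.3-fold higher number from compound 1 to compound 4 (0.10 log units; within the scatter), stays within the scatter. Going by these compounds alone, the 4-iodophenyl of compound 1 is thus not separated from either the 3,4-dimethylphenyl or the 3-methoxyphenyl, and no evidence is available to explain the one step that exceeds the scatter.

The compounds shown leave open how a 4-methoxyphenyl or a 3-methylphenyl would compare on this core. They also leave open whether an aryl group carrying an amine or a carboxylic acid would move the number further in either direction.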